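The source may hold more compounds than are shown below. What is called first, only, known or untested is meant among the compounds shown, and "the series" means these compounds.

Measured so far:
- compound 1 `CC(C)COC(=O)N1CCCc2cc(S(=O)(=O)N3CC(c4ccccc4)NC3=O)ccc21`: > 20000 nM (a limit)
- compound 2 `O=C(CCl)N1CCCc2cc(S(=O)(=O)N3CC(c4ccccc4)NC3=O)ccc21`: "not determined" (no result reported)

In a functional assay on A549 cells (Homo sapiens) for antiproliferative activity, read by MTT assay (a lower number here means a stronger inhibitor, a higher number a weaker inhibitor), compound 2 has no single number, its entry reading "not determined" (no result reported). Within the data shown here, the only other reading in this small set belongs to compound 1, which gives > 20000 nM, and that is a limit of the assay, not a number. Compound 3 `O=C1NC(c2ccccc2)CN1S(=O)(=O)c1ccc2c(c1)CCCN2C(=O)C(F)(F)F` is the next compound to be tested. The change is trifluoromethyl in place of chloromethyl on a carbonyl carbon. With no number for compound 2, the step has no starting value, so neither a size nor a direction can be expected from it in this assay. The expectation therefore stays weak and rests only on the limit reached by compound 1 at > 20000 nM. For compound 3 the expected value is 10000 nM, with an estimated range of 2000 nM to 30000 nM.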

Compound 3, half-maximal inhibitory concentration: > 20000 nM
Compound 3 ended at the assay's limit; the forecaster's own chance of this, stated with the estimate: 40%; middle value at least 2.0-fold (0.30 log units) away from the limit.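

In this assay no step can be read from compound 1 to compound 3 or from compound 2 to compound 3, and compound 1 and compound 3 rest at the same limit: the limit of > 20000 nM in this assay, at which 2 of the 3 values shown sit.
The compounds shown leave open whether any group on the carbonyl carbon of the shared core gives a readable value in this assay at all.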